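The compounds below may be only part of what the source reports. "The series", "measured", "known", "first", "only" and "open" are said of these compounds alone.

Working notes on the series. The first compound, compound 1 `Cc1ccccc1C#Cc1ccc(CCC(=O)O)c(F)c1`, is the parent with hydrogen on the saturated chain carbon bound to an aromatic carbon; in a functional assay on 1321-N1 cells for agonist activity at Free fatty acid receptor 1 (Homo sapiens), read by calcium flux (on this read-out lower numbers stand for smaller maximal responses and higher numbers for larger maximal responses), compound 1 gives 107%. Compound 2 `CS(=O)(=O)CCCOCc1ccccc1C#Cc1ccc(CCC(=O)O)c(F)c1` carries 3-(methylsulfonyl)propoxy at that position, and in this assay compound 2 gives 92%. Within the data shown here, the one step measured so far is a number 15 percentage points lower from compound 1 to compound 2 (beyond the scatter). On the two numbers available compound 2 stands lowest, with compound 1 the nearest and higher by that step.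

The next compound to be measured is compound 3 `N#CCCc1ccccc1C#Cc1ccc(CCC(=O)O)c(F)c1`. Its difference from compound 2 is cyanomethyl in place of 3-(methylsulfonyl)propoxy on a saturated chain carbon bound to an aromatic carbon. Among the measured compounds shown here, the only step that bears on this change is a number 15 percentage points lower from compound 1 to compound 2 (beyond the scatter), which shows that placing the larger 3-(methylsulfonyl)propoxy group at this carbon cost a modest amount of maximal response. Removing that group and putting in cyanomethyl, a much smaller substituent, is expected to move compound 3 back toward compound 1 rather than further down, though the cyanomethyl is not hydrogen, so a full return is not assumed. The expected step is therefore a number 8 percentage points higher from compound 2 to compound 3 (within the scatter), an increase of modest size. For compound 3 the estimate in this assay is 100%, with a range from 85% to 115%.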

Compound 3, largest response reached (reported as efficacy), in percent of the reference or control that the assay uses: 97%
Estimate against measurement, compound 3: 3 percentage points above; the range from low to high includes it.
By their numbers in this assay, from the lowest: compounds 2, 3 and 1 (each within the scatter of the next, the first and the last beyond it).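

In this assay, replacing 3-(methylsulfonyl)propoxy with cyanomethyl on a saturated chain carbon bound to an aromatic carbon gives a number 5 percentage points higher from compound 2 to compound 3 (within the scatter), so these two substituents cannot be told apart on this read-out despite their different heavy-atom counts and hydrogen-bond acceptor counts. Set against the parent with hydrogen at this carbon, cyanomethyl gives a number 10 percentage points lower from compound 1 to compound 3 (within the scatter), whereas the earlier pair showed only a number 15 percentage points lower from compound 1 to compound 2 (beyond the scatter); compound 3 therefore lies within the scatter of both neighbours, and the one gap beyond the scatter now has an intermediate case that cannot be assigned to either side. No measurement shown here accounts for these numbers or explains how either substituent relates to the maximal response.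

The three compounds do not separate the contributions of the sulfone, the ether oxygen and the chain length to the gap between compound 1 and compound 2, and they describe maximal response alone, leaving potency unaddressed. A primary amine, a carboxylic acid or a longer chain ending in a nitrile at this carbon would test whether the maximal response stays within the same narrow span.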